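Sulfonyl substituent swap in the urea series: solubility notes

The source may hold more compounds than are shown below. What is called first, only, known or untested is meant among the compounds shown, and "the series" means these compounds.

Measured so far in a physicochemical assay for solubility, in phosphate buffer, with a stated time of 24 h, at pH 7.4, tested at 100 uM; on this read-out lower numbers stand for lower solubility and higher numbers for higher solubility:
compound 1 `O=C(NCc1ccc(S(=O)(=O)c2ccccc2)cc1)NCc1cccnc1` gives 10000 nM
compound 2 `CC(C)n1cc(S(=O)(=O)c2ccc(CNC(=O)N3Cc4ccncc4C3)cc2)cn1` gives 192000 nM
compound 3 `CC(=O)N1CCC(S(=O)(=O)c2ccc(CNC(=O)N3Cc4ccncc4C3)cc2)CC1` gives 187000 nM

Compound 2 has the highest number of the three. For the measured compounds named here, compound 3 stands nearest, the pair being within the scatter, so no order between them can be read; compound 1 stands furthest, with a clearly lower number, but it differs from compound 2 in more than one place and no single step connects them.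

Compound 4 `CN1CCN(S(=O)(=O)c2ccc(CNC(=O)N3Cc4ccncc4C3)cc2)CC1` is not yet measured. It differs from compound 2 as follows: 4-methylpiperazin-1-yl in place of 1-isopropyl-1H-pyrazol-4-yl on a sulfonyl sulfur.

Going by the values given here, the one step that bears on this is the exchange of the group on the sulfonyl sulfur from compound 2 to compound 3, which gave a 1.0-fold lower number from compound 2 to compound 3 (0.01 log units; within the scatter). That swap of a five-membered aromatic ring for a six-membered non-aromatic ring left the read-out unchanged within the scatter, and the change to compound 4 is of the same kind at the same place. Among the compounds with values here, no measured step shows a shift at this position, so no step beyond the scatter is expected for compound 4, with a slight lean to a higher number; the expected step is a 1.2-fold higher number from compound 2 to compound 4 (0.08 log units; within the scatter).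

Compound 4 is therefore estimated at 230000 nM, with the range 110000 nM to 480000 nM.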

Compound 4, solubility: 160000 nM
For compound 4 the middle estimate is 1.4-fold (0.16 log units) above the measured one, within the range that was stated.
By their numbers in this assay, from the lowest: compound 1; then compounds 4, 3 and 2 (each within the scatter of the next).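

With 4-methylpiperazin-1-yl on the sulfonyl sulfur, this assay stays within the scatter of both earlier groups (a 1.2-fold lower number from compound 2 to compound 4 (0.08 log units; within the scatter)) and (a 1.2-fold lower number from compound 3 to compound 4 (0.07 log units; within the scatter)). Where the earlier compounds offered a single exchange at this place, three groups now sit on the same core, and no order among compounds 2, 3 and 4 can be read. The flat result also extends to a group joined to the sulfur through a ring nitrogen, whereas the groups of compounds 2 and 3 are joined through a ring carbon.

From the compounds shown here alone, whether a carboxylic acid, a primary amine or a plain alkyl chain on the sulfonyl sulfur would leave this read-out equally unmoved stays open. Nothing in hand accounts for the flat result at this position.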